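The source may hold more compounds than are shown below. What is called first, only, known or untested is meant among the compounds shown, and "the series" means these compounds.

Among the three compounds measured in a functional assay on UACC-62 cells (Homo sapiens) for cytotoxicity, read by MTT assay, with a stated time of 6 days (a higher number here means a weaker inhibitor, a lower number a stronger inhibitor), compound 3, with structure `CC(=O)N[C@@H](CSC(=O)Nc1ccccc1)C(=O)O`, has the highest number: compound 3 gives 125000 nM. Compound 1, `CC(=O)N[C@@H](CSC(=O)Nc1ccc(I)cc1)C(=O)O`, sits nearest, at 46200 nM, while compound 2, `CC(=O)N[C@@H](CSC(=O)Nc1ccc(Cl)cc1)C(=O)O`, gives 24 nM and lies furthest away. Compound 4, `CSc1ccccc1NC(=O)SC[C@H](NC(C)=O)C(=O)O`, has not yet been tested; it differs from compound 3 by methylsulfanyl in place of hydrogen on an aromatic carbon.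

The measured steps all concern the same kind of change, a group entering or leaving an aromatic carbon of the shared core. Removal of the chloro group brought a 5200-fold higher number from compound 2 to compound 3 (3.72 log units; beyond the scatter), and removal of the iodo group brought a 2.7-fold higher number from compound 1 to compound 3 (0.43 log units; beyond the scatter). Both removals raised the number, though by very different amounts, and neither involves a methylsulfanyl group or a position ortho to a large group, so they offer only loose guidance. A modest step downward, a 3.1-fold lower number from compound 3 to compound 4 (0.49 log units; beyond the scatter), is therefore expected, with wide uncertainty; the value for compound 4 is estimated at 40000 nM, within 2000 nM to 200000 nM.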

Compound 4, half-maximal inhibitory concentration: > 200000 nM
Compound 4 ended at the assay's limit (the forecaster's own chance of this, stated with the estimate: 10%); middle value at least 5.0-fold (0.69 log units) away from the limit.
By their numbers in this assay, from the lowest: compound 2; then compound 1; then compound 3. At a limit, above all of these: compound 4.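

In this assay, compound 4 gives > 200000 nM, which is a limit of the assay and not a number: the limit of > 200000 nM in this assay, at which 1 of the 4 values shown sits.

Within the data shown here, the step reads an at least 1.6-fold higher number from compound 3 to compound 4 (0.20 log units; that floor lies within the scatter), so methylsulfanyl in place of hydrogen, ortho to a large group, brought no drop in the number, the first sign that a group at this place does not lower it. Because only a floor is known, the data cannot say how far the number rose, or whether the true rise lies beyond the scatter.

From the compounds shown here alone, what an amine, a hydroxyl group or a methyl group would do at this same place remains open. So does the question of whether methylsulfanyl would give a similar result on another carbon of the aromatic ring.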